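Aryl change on the sulfonyl sulfur: expected half-life

The source may hold more compounds than are shown below. What is called first, only, known or untested is meant among the compounds shown, and "the series" means these compounds.

Compound 1 `CC1CCN(C2CCN(S(=O)(=O)c3cccc(Br)c3)CC2)CC1` has the lowest of the two numbers measured in an ADME assay on S9 fraction from liver (Mus musculus, strain ICR/CD-1) for metabolic stability, read by LC-MS, using NADPH, with a stated time of 5 min, tested at 2 uM (on this read-out higher numbers stand for a longer-lived compound and lower numbers for a shorter-lived compound), giving 0.217 h; compound 2 `COc1ccccc1-c1cccc(S(=O)(=O)N2CCC(N3CCC(C)CC3)CC2)c1` gives 0.25 h. Among the compounds with values here, the only measured step, a 1.2-fold higher number from compound 1 to compound 2 (0.06 log units; within the scatter), puts 2-methoxyphenyl in place of bromo on an aromatic carbon and stays within the scatter. Compound 3 `CC1CCN(C2CCN(S(=O)(=O)c3ccc(Cl)cc3Cl)CC2)CC1` differs from compound 1 by 2,4-dichlorophenyl in place of 3-bromophenyl on a sulfonyl sulfur. Within the data shown here, no measured step matches this change, and the one step that bears on it, a 1.2-fold higher number from compound 1 to compound 2 (0.06 log units; within the scatter), was within the scatter. The expected step is therefore a 1.0-fold higher number from compound 1 to compound 3 (0.01 log units; within the scatter), none beyond the scatter. Compound 3 is estimated at 0.22 h, range 0.11 h to 0.45 h.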

Compound 3, half-life: 0.25 h
Compound 3: the middle estimate sits 1.1-fold (0.06 log units) below what was measured; measured number inside the range.
By their numbers in this assay, from the lowest: compounds 1, 2 and 3 (each within the scatter of the next).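

In this assay, 2,4-dichlorophenyl in place of 3-bromophenyl on a sulfonyl sulfur gives a 1.2-fold higher number from compound 1 to compound 3 (0.06 log units; within the scatter), so a change of halogen and of substitution pattern on this aryl group does not separate the two compounds. The aryl group on the sulfonyl sulfur has now been exchanged with the core of compound 1 held constant, and this direct exchange stays within the scatter. No evidence on the origin of this result is available.

Still open, from the compounds shown here alone, is whether an aryl group carrying an amine or a carboxylic acid would move the half-life beyond the scatter. The same applies to a simple alkyl chain on the sulfonyl sulfur.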